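Phosphorus epimer of an acyloxymethyl phosphonate prodrug

The source may report more compounds than this note shows. Statements on the series, on what has been measured and on what is new or still open speak of the compounds shown alone.

Measured so far in an ADME assay on blood (Homo sapiens) for pharmacokinetics; on this read-out higher numbers stand for a longer-lived compound and lower numbers for a shorter-lived compound:
- compound 1, `COC(=O)CCNC(=O)[C@@H]1O[P@@](=O)(OCOC(=O)c2ccns2)OCC1(C)C`: < 0.16 h
- compound 2, `COC(=O)CCNC(=O)[C@@H]1O[P@](=O)(OCOC(=O)c2scnc2C)OCC1(C)C`: < 0.16 h

Compound 1 returns only a limit of this assay, < 0.16 h. Compound 2 likewise returns only a limit, < 0.16 h. Both values therefore sit at the limit of < 0.16 h in this assay, at which 2 of the 2 values shown sit, so compound 2 is not placed by a number at all; it stands at the limit together with compound 1, and no ordering between the two can be read from this.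

Compound 3, `COC(=O)CCNC(=O)[C@@H]1O[P@@](=O)(OCOC(=O)c2scnc2C)OCC1(C)C`, has not been measured in this assay. Its relation to compound 2 is the two compounds have the same atoms and bonds and differ only in configuration as drawn: 1 of 2 stereo elements differ; a stereocentre at a phosphorus is drawn R in compound 2 and S in compound 3. Among the compounds with values here, no measured pair differs in one place, so no measured step guides the expectation; the step from compound 2 to compound 3 is expected to be small in this assay, in no particular direction, and not beyond the scatter, a step that the limit leaves unreadable from compound 2 to compound 3.

Compound 3 is expected to give 0.1 h in this assay, within 0.04 h to 0.3 h, most probably reported again only as a limit.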

Compound 3, half-life: > 1 h
Compound 3 was reported as a limit; the forecaster's own chance of this, stated with the estimate: 80%; middle value at least 10-fold (1.00 log units) away from the limit.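

In this assay the configuration at phosphorus alone carries a step beyond the scatter, an at least 6.2-fold higher number from compound 2 to compound 3 (0.79 log units; beyond the scatter), and no other structural difference exists to account for it: the fact that compounds 2 and 3 differ only in the configuration as drawn

The group on the carbonyl carbon also shows a step, an at least 6.2-fold higher number from compound 1 to compound 3 (0.79 log units; beyond the scatter), with 4-methyl-1,3-thiazol-5-yl in place of 1,2-thiazol-5-yl.

Compound 3 returns only a limit of the assay, > 1 h, so the full size of both steps cannot be read.

From the compounds shown here alone, it remains open whether the phosphorus configuration gives a comparable step with 1,2-thiazol-5-yl or with a phenyl group on the carbonyl carbon. Equally open, going by these compounds, is how the half-life responds when a carboxylic acid replaces the methyl ester.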